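A few compounds are considered here, and "the series" means these few. Any claim that something is new, unique, unknown or untested is made for them only; others in the source may bear on it.

The measured compounds: compound 1 `CN(C)CCn1cnnc1-c1cc(Oc2ccc(NC(=O)N/N=C/c3c(Cl)cccc3Cl)cc2F)ccn1` gives 3320 nM in an ADME assay on WI-38 cells (Homo sapiens) for cytotoxicity, read by MTT assay, with a stated time of 72 h; a lower number here means a stronger inhibitor, a higher number a weaker inhibitor; compound 2 `CN(C)CCn1cnnc1-c1cc(Oc2ccc(NC(=O)N/N=C/c3c[nH]c4ccccc34)cc2F)ccn1` gives 3620 nM; compound 3 `CN(C)CCn1cnnc1-c1cc(Oc2ccc(NC(=O)N/N=C/c3cc(C(C)(C)C)cc(C(C)(C)C)c3O)cc2F)ccn1` gives 2350 nM.

All three numbers lie within the scatter of one another. Compound 2 sits nearest to compound 1, and the gap to compound 3 is also within the scatter, so no ordering among the three can be claimed.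

Compound 4 `CN(C)CCn1cnnc1-c1cc(Oc2ccc(NC(=O)N/N=C/c3ccc(O)c(Br)c3)cc2F)ccn1` differs from compound 2 in one place: 3-bromo-4-hydroxyphenyl in place of 1H-indol-3-yl on a carbon with a double bond to nitrogen. Within the data shown here, the only measured step at this same carbon is a 1.1-fold higher number from compound 1 to compound 2 (0.04 log units; within the scatter), which did not move the number beyond the scatter. The pair compound 2 and compound 3, which also differ at this carbon, show values within the scatter of each other. Among the measured compounds shown here, nothing among the measured compounds therefore points to a change beyond the scatter in this assay for a new group at this carbon.

The expected step is a 1.1-fold lower number from compound 2 to compound 4 (0.04 log units; within the scatter). Compound 4 is accordingly estimated at 3300 nM, with a range from 1500 nM to 7500 nM.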

Compound 4, half-maximal inhibitory concentration: 5560 nM
The estimate for compound 4 lay 1.7-fold (0.23 log units) below the measured number; the measured number falls inside the stated range.
By their numbers in this assay, from the lowest: compounds 3, 1, 2 and 4 (each within the scatter of the next, the first and the last beyond it).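

In this assay, 3-bromo-4-hydroxyphenyl on the carbon with a double bond to nitrogen stays within the scatter of both groups it can be read against, with a 1.5-fold higher number from compound 2 to compound 4 (0.19 log units; within the scatter) and a 1.7-fold higher number from compound 1 to compound 4 (0.22 log units; within the scatter). Yet compound 3 at 2350 nM and compound 4 at 5560 nM are the only pair among the four whose values lie beyond the scatter of each other, so changes at this carbon can separate compounds in this assay, though only across the full span of the set. Nothing measured here bears on why the values spread in this way.

The compounds shown leave open whether the bromine or the hydroxyl of the new group matters on its own. They also leave open whether an aliphatic amine or a carboxylic acid at this carbon would give a number outside this span.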